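The source may hold more compounds than are shown below. What is called first, only, known or untested is meant among the compounds shown, and "the series" means these compounds.

Compound 1 `Cc1n[nH]c2ccc(-c3nc4cnc(N5CCN(C)CC5)cn4c3Nc3ccccc3Cl)cc12`: "not determined" (no result reported) in a functional assay on MV4-11 cells (Homo sapiens) for inhibition, with a stated time of 120 h; a higher number here means a weaker inhibitor, a lower number a stronger inhibitor
Compound 2 `Cc1n[nH]c2ccc(-c3nc4cnc(N5CCN(C)CC5)cn4c3Nc3cccc(Cl)c3)cc12`: "not determined" (no result reported)
Compound 3 `Cc1cc(Br)ccc1Nc1c(-c2ccc3[nH]nc(C)c3c2)nc2cnc(N3CCN(C)CC3)cn12`: 10900 nM

Compound 1 stands without a number in this assay; compound 2 likewise has none, so the only measured value among these three belongs to compound 3. The change from compound 1 to compound 4 `Cc1n[nH]c2ccc(-c3nc4cnc(N5CCN(C)CC5)cn4c3Nc3ccc(F)cc3Br)cc12` is 2-bromo-4-fluorophenyl in place of 2-chlorophenyl on a nitrogen on an aromatic ring. Among the measured compounds shown here, with no measured pair of this kind, no step can be taken from the data; compound 3, which also carries two substituents on the ring attached to that nitrogen, gives the only anchor, and its value is a weak one. Compound 4 is therefore expected to land near that anchor, at an estimated 9000 nM, with a plausible range from 2500 nM to 32000 nM.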

Compound 4, half-maximal inhibitory concentration: 3830 nM
Estimate against measurement, compound 4: 2.3-fold (0.37 log units) above; the measured number falls inside the stated range.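

In this assay the group on this nitrogen proves able to move the read-out: the number falls a 2.8-fold lower number from compound 3 to compound 4 (0.45 log units; beyond the scatter) when 2-bromo-4-fluorophenyl stands in place of 4-bromo-2-methylphenyl. Among the compounds shown here, this is the first measured step at this position, and a modest one, with compound 4 at 3830 nM in the micromolar range. No measurement shown here accounts for the change.

On these data alone, compound 1 and compound 2 carry no number, so what a lone chlorine does on this ring stays open. Also open, as far as these compounds go, is how an amine or a carboxylic acid on the ring would read.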